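Nitro for bromo on one aryl of compound 1

The source may report more compounds than this note shows. Statements on the series, on what has been measured and on what is new or still open speak of the compounds shown alone.

Among the compounds with values here, compound 1 `N#CCC1=NN=C(c2ccc(Br)cc2)C(Br)O1` gives 38200 nM in a functional assay on NCI-H460 cells (Homo sapiens) for inhibition, read by sulforhodamine B assay, with a stated time of 48 h (on this read-out higher numbers stand for weaker inhibition of growth and lower numbers for stronger inhibition of growth), and thus holds the highest number of the three measured so far. Compound 3 `N#CCC1=NN=C(c2ccc(Br)cc2)C(CC(=O)c2ccc([N+](=O)[O-])cc2)O1` gives 23000 nM, within the scatter of compound 1. Compound 2 `N#CCC1=C(C#N)CC(c2ccc(Br)cc2)=C(CC(=O)c2ccc(Br)cc2)O1` gives 10400 nM, a number that lies beyond the scatter below compound 1. Compound 4 `N#CCC1=NN=C(c2ccc([N+](=O)[O-])cc2)C(Br)O1` is not yet measured. Against compound 1 it differs by nitro in place of bromo on an aromatic carbon. Within the data shown here, no measured pair isolates this change on the shared core, so the three measured compounds give no direct guide to its size. The expected step is a 1.3-fold lower number from compound 1 to compound 4 (0.10 log units; within the scatter), small and with no direction established beyond the scatter. Compound 4 is estimated at 30000 nM, with a range of 10000 nM to 90000 nM.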

Compound 4, concentration for 50% growth inhibition: 8500 nM
For compound 4 the middle estimate is 3.5-fold (0.55 log units) above the measured one; the whole stated range lies above it.
By their numbers in this assay, from the lowest: compounds 4 and 2 (each within the scatter of the next); then compounds 3 and 1 (each within the scatter of the next).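

Nitro in place of bromo on an aromatic carbon, para to a large group, gives a 4.5-fold lower number from compound 1 to compound 4 (0.65 log units; beyond the scatter) in this assay and is the only step here that isolates a single change. It lies beyond the scatter, so this position on the shared core does respond to its substituent, with nitro giving stronger inhibition of growth than bromo. Nothing measured on these compounds bears on what lies behind the step.

On these data alone, whether an amine or a methoxy group at this position would give a number on the nitro side or the bromo side remains open. So does whether the same change gives a similar step when the other bromo of compound 1 is replaced by a longer chain.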